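This account rests on a few compounds, and the source may have more. Where it says the series, first, only, none or still open, it means among the compounds named here.

Measured so far in an ADME assay on CHO cells (Cricetulus griseus) for inhibition, read by MTT assay; a lower number here means a stronger inhibitor, a higher number a weaker inhibitor:

Compound 1, `CC(C)(C)NCc1cc(C(C)(C)C)cc(Nc2nc3ccccc3[nH]2)c1O`, gives 30500 nM.
Compound 2, `CC(C)(C)NCc1cc(C(C)(C)C)cc(Nc2nc3cc(F)c(F)cc3[nH]2)c1O`, gives 34200 nM.
Compound 3, `Cc1cc(CNC(C)(C)C)c(O)c(Nc2nc3cc(F)c(F)cc3[nH]2)c1`, gives 16700 nM.

Compound 1 and compound 2 sit on different cores; the difference between the two cores is not broken down here. Their values in this assay lie within the usual scatter of one another, so nothing is read into their order. On the core of compound 2 a single change has been measured: methyl in place of tert-butyl on an aromatic carbon. That change produced a 2.0-fold lower number from compound 2 to compound 3 (0.31 log units; beyond the scatter).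

Compound 4, `Cc1cc(CNC(C)(C)C)c(O)c(Nc2nc3ccccc3[nH]2)c1`, has not yet been measured in this assay. It carries the same change applied to the core of compound 1: methyl in place of tert-butyl on an aromatic carbon. The surroundings of the place are described in the same words for both pairs, so this is taken as the same change and not merely the same kind. Within the data shown here, only one measured instance exists, and the other core is not broken down, so the expectation rests on that single step alone.

The step from compound 1 to compound 4 in this assay is expected to be a 2.0-fold lower number from compound 1 to compound 4 (0.29 log units; within the scatter), close to the measured one, because compound 1 gives 30500 nM and the matched pair gave a 2.0-fold lower number from compound 2 to compound 3 (0.31 log units; beyond the scatter). On that basis compound 4 is estimated at 15500 nM in this assay, with the likely range running from 8000 nM to 30000 nM.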

Compound 4, half-maximal inhibitory concentration: 33300 nM
For compound 4 the middle estimate is 2.1-fold (0.33 log units) below the measured one; measured number outside the range, above it.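

Carried to the other core, methyl in place of tert-butyl on an aromatic carbon gives a 1.1-fold higher number from compound 1 to compound 4 (0.04 log units; within the scatter) in this assay, so no shift can be read on this core. Set beside the earlier step, this instance cannot be told apart from it, and the data give no sign that the two cores respond differently: the same change on two cores in this assay, a 2.0-fold lower number (0.31 log units; beyond the scatter) from compound 2 to compound 3 and a 1.1-fold higher number (0.04 log units; within the scatter) from compound 1 to compound 4, 2.2-fold (0.35 log units) apart, within the scatter of two such steps. Among these compounds, this does not show that the change carries across with a fixed size, since only one of the two steps lies beyond the scatter, and it does not show that the outcome depends on the core; two instances settle neither reading, so any transfer of this change remains weakly supported.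

The compounds shown leave open how the number would respond on either core to other groups at the same aromatic carbon, such as ethyl, isopropyl, methoxy or trifluoromethyl. Also open, as far as these compounds go, is whether the change would behave alike if the ((tert-butyl)amino)methyl group gave way to another amine, such as a dimethylamino or morpholine group.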